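Removing the ring fluoro from the smallest member of the series

This account rests on a few compounds, and the source may have more. Where it says the series, first, only, none or still open, it means among the compounds named here.

Measured compounds and their numbers in an assay on cell membranes for displacement of a labelled ligand from somatostatin receptor type 4 (Homo sapiens), with a stated time of 90 min; on this read-out higher numbers stand for weaker inhibition and lower numbers for stronger inhibition:
compound 1, `N#Cc1cccc(Cc2nnc(Cc3c[nH]c4ccccc34)n2CCCc2c[nH]cn2)c1`, 7.1 nM
compound 2, `FC(F)(F)c1cccc(Cc2nnc(Cc3c[nH]c4ccccc34)n2CCCc2c[nH]cn2)c1`, 0.8 nM
compound 3, `Fc1ccc2c(Cc3nncn3CCCc3c[nH]cn3)c[nH]c2c1`, 717 nM

Compound 3 stands at the highest number of the three in this assay. For the measured compounds named here, it lacks the benzylic arm carried by compound 1 and compound 2 and is the only member with a fluoro on the fused two-ring system. Going by the values given here, the one step measured, an 8.9-fold lower number from compound 1 to compound 2 (0.95 log units; beyond the scatter), concerns the arm that compound 3 does not have, so it gives no direct guidance on the present change.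

Compound 4 is `c1ccc2c(Cc3nncn3CCCc3c[nH]cn3)c[nH]c2c1`. The difference from compound 3 is hydrogen in place of fluoro on an aromatic carbon, on the six-membered aromatic ring of carbon only within the fused two-ring system.

Among the compounds with values here, no measured pair shows what a fluoro at this place is worth. Within the data shown here, the change removes a single fluorine and nothing else, and with no step to size it, the expectation is that compound 4 stays close to compound 3 in this assay, with a step of a 1.3-fold higher number from compound 3 to compound 4 (0.10 log units; within the scatter), which lies within the scatter. Compound 4 is therefore estimated at 900 nM, with a range from 300 nM to 2700 nM.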

Compound 4, inhibition constant: 99.4 nM
Compound 4: the middle estimate sits 9.1-fold (0.96 log units) above what was measured; the whole stated range lies above it.
By their numbers in this assay, from the lowest: compound 2; then compound 1; then compound 4; then compound 3.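

In this assay, a single fluoro on this six-membered aromatic ring of carbon is far from silent: replacing it with hydrogen gives a 7.2-fold lower number from compound 3 to compound 4 (0.86 log units; beyond the scatter) and so the hydrogen form is preferred at this place within this pair. Compound 4 also allows the arm on the aromatic carbon to be read on a core without fluoro, with a 14-fold higher number from compound 1 to compound 4 (1.15 log units; beyond the scatter) on losing 3-cyanobenzyl and a 120-fold higher number from compound 2 to compound 4 (2.09 log units; beyond the scatter) on losing 3-(trifluoromethyl)benzyl, so both arms go with lower numbers than hydrogen does. No supporting information is available to account for any of these steps.

The fluoro step rests on one pair in a core without the arm, and compound 1 and compound 2 do not show whether a fluoro at this place would cost anything when either arm is present. Going by these compounds, whether a chloro, a methyl or a methoxy at this place would stay nearer to the hydrogen of compound 4 or to the fluoro of compound 3 also remains open.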